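Swapping fluorine for bromine on a borate salt

The source may report more compounds than this note shows. Statements on the series, on what has been measured and on what is new or still open speak of the compounds shown alone.

Of the compounds shown here, three have been tested in an assay on HEK293 cells for inhibition of transient receptor potential cation channel subfamily V member 6 (Homo sapiens), read by FLIPR and calcium flux, with a stated time of 5 min; on this read-out higher numbers stand for weaker inhibition and lower numbers for stronger inhibition. Compound 1, `COc1ccccc1B(O)c1ccccc1OC`, gives only a limit in this assay: > 500000 nM. Compound 2, `OB(c1ccc(F)cc1)c1ccc(F)cc1`, gives a number, 37100 nM. Compound 3, `Fc1ccc([B-]2(c3ccccc3)[NH2+]CCO2)cc1`, gives 18800 nM in this assay. So compound 3 holds one of only two proper numbers, the other belonging to compound 2, and the values of compound 2 and compound 3 sit within the usual scatter of each other, so they cannot be told apart.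

The next compound, compound 4, `Brc1ccc([B-]2(c3ccccc3)[NH2+]CCO2)cc1`, has not yet been measured. Among the compounds with values here, its single change from compound 3 is bromo in place of fluoro on an aromatic carbon; that is, a bromo group in place of a fluoro group on an aromatic carbon, on a six-membered aromatic ring of carbon only, para to a large group. Within the data shown here, no measured pair in this set shows what such a swap does, so there is nothing to calibrate the step against.

With no guide from the data, compound 4 is expected to stay close to compound 3, with at most a small change in either direction, an expected step of a 1.4-fold lower number from compound 3 to compound 4 (0.16 log units; within the scatter). The estimate for compound 4 in this assay is 13000 nM, expected to fall between 4000 nM and 40000 nM.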

Compound 4, half-maximal inhibitory concentration: 13200 nM
The estimate for compound 4 lay 1.0-fold (0.01 log units) below the measured number; measured number inside the range.
By their numbers in this assay, from the lowest: compounds 4, 3 and 2 (each within the scatter of the next, the first and the last beyond it). At a limit, above all of these: compound 1.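

Putting bromo in place of fluoro on an aromatic carbon, para to a large group, gives a 1.4-fold lower number from compound 3 to compound 4 (0.15 log units; within the scatter), so in this assay the two compounds cannot be told apart. Within the data shown here, this is the first pair in the set that differs in only one place, and it shows that, at this position on the shared core, a fluoro group and a bromo group serve equally well on this read-out, though a single pair is too little to build a wider pattern on. Nothing measured here accounts for this outcome, and no other property of the two compounds is available to set beside it.

From the compounds shown here alone, what remains open is whether this position needs a substituent at all, and how the read-out would respond to a different kind of group there, such as a methoxy group, an amine or a carboxylic acid. Going by these compounds, the second aromatic ring of the shared core also carries no group in compound 3 or compound 4, so the effect of placing even a simple chloro or methyl group on that ring remains unknown.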